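Methoxy to hydroxy in the (4-methoxyphenyl)amino group

The source may report more compounds than this note shows. Statements on the series, on what has been measured and on what is new or still open speak of the compounds shown alone.

Measured compounds:
compound 1 `COc1ccc(Nc2nc(/C=C/c3cc(OC)c(OC)c(OC)c3)nc3ccsc23)cc1`: 10700 nM
compound 2 `COc1cc(/C=C/c2nc(Nc3ccc(C(F)(F)F)cc3)c3sccc3n2)cc(OC)c1OC`: 9360 nM

Going by the values given here, in a functional assay on RAW264.7 cells (Mus musculus) for inhibition, read by Griess assay, with stated times of 1 h and 24 h (on this read-out lower numbers stand for stronger inhibition and higher numbers for weaker inhibition), compound 1 has only compound 2 beside it, and the one measured step, a 1.1-fold lower number from compound 1 to compound 2 (0.06 log units; within the scatter), lies within the scatter, so compound 1 is not separated from compound 2 on these numbers.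

Compound 3 `COc1cc(/C=C/c2nc(Nc3ccc(O)cc3)c3sccc3n2)cc(OC)c1OC` differs from compound 1 by hydrogen in place of methyl on an oxygen on an aromatic ring. Among the compounds with values here, no measured step covers this change: the single step concerns trifluoromethyl in place of methoxy, not hydrogen in place of methyl on the oxygen, and it stayed within the scatter. A step of a 1.1-fold lower number from compound 1 to compound 3 (0.03 log units; within the scatter) is therefore expected, none beyond the scatter. Compound 3 is estimated at 10000 nM, range 3500 nM to 30000 nM.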

Compound 3, half-maximal inhibitory concentration: 4070 nM
Beside the measured number, compound 3's estimate is 2.5-fold (0.39 log units) above it; measured number inside the range.
By their numbers in this assay, from the lowest: compound 3; then compounds 2 and 1 (each within the scatter of the next).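

Going by these compounds alone, at the 4-position group of the (4-hydroxyphenyl)amino series, hydroxy is the first group to separate from the others in this assay (a 2.6-fold lower number from compound 1 to compound 3 (0.42 log units; beyond the scatter)) and (a 2.3-fold lower number from compound 2 to compound 3 (0.36 log units; beyond the scatter)), whereas methoxy and trifluoromethyl were not separated. The number therefore does respond to the group at this place, though both steps are modest. No measured evidence bearing on the reason accompanies these numbers.

Whether the lower number is particular to hydroxy stays open, as the compounds shown do not say how an amine or a carboxylic acid at this place would read. They also leave open whether the hydrogen on the oxygen alone accounts for the step, which a comparison with an ethoxy group would not settle by itself.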